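This account rests on a few compounds, and the source may have more. Where it says the series, first, only, none or still open, it means among the compounds named here.

Measured in a functional assay on HeLa cells (Homo sapiens) for antiproliferative activity, read by CCK-8 assay, with a stated time of 48 h; a higher number here means a weaker inhibitor, a lower number a stronger inhibitor:
- compound 1 `COc1ccc(/C=C\c2cc(OC)c(OC)c(OC)c2)cc1OCc1ccc(CN2CCCC[C@@H]2C(=O)O)cc1`: > 10000 nM
- compound 2 `COc1ccc(/C=C\c2cc(OC)c(OC)c(OC)c2)cc1OCc1ccc(CO)cc1`: 7600 nM

Compound 1 reports > 10000 nM, which is a limit of the assay and not a number. Among the compounds with values here, compound 2, at 7600 nM, therefore holds the only true number in this assay. Compound 3 `COc1ccc(/C=C\c2cc(OC)c(OC)c(OC)c2)cc1OCc1ccc(CN2CC(C(=O)O)C2)cc1` carries 3-carboxyazetidin-1-yl in place of hydroxy on a saturated chain carbon bound to an aromatic carbon. Within the data shown here, the one measured step that bears on this change is the swap of 2-carboxypiperidin-1-yl for hydroxy, an at least 1.3-fold lower number from compound 1 to compound 2 (0.11 log units; that floor lies within the scatter). That step gives only a floor, and the new change runs the opposite way, so a higher number is expected. The expected change is a 1.6-fold higher number from compound 2 to compound 3 (0.20 log units; within the scatter). For compound 3 the estimated value is 12000 nM, with an expected range of 4000 nM to 30000 nM.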

Compound 3, half-maximal inhibitory concentration: 6500 nM
Compound 3: middle estimate off by 1.8-fold (0.27 log units), on the high side; the measured number falls inside the stated range.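

In this assay, this saturated chain carbon bound to an aromatic carbon accepts 3-carboxyazetidin-1-yl in place of hydroxy with a 1.2-fold lower number from compound 2 to compound 3 (0.07 log units; within the scatter), so compound 2 and compound 3 cannot be ranked. Compound 1 stands at a limit of the assay and not a number: the limit of > 10000 nM in this assay, at which 1 of the 3 values shown sits. The exchange of its 2-carboxypiperidin-1-yl for 3-carboxyazetidin-1-yl therefore gives only a floor, an at least 1.5-fold lower number from compound 1 to compound 3 (0.18 log units; that floor lies within the scatter), and the two groups cannot be ranked either.

On these data alone, it remains open whether a plain amine without the carboxylic acid, or a longer chain carrying the carboxylic acid, would move the number beyond the scatter.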